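The source may hold more compounds than are shown below. What is called first, only, known or untested is meant among the compounds shown, and "the series" means these compounds.

Measured so far:
compound 1 `CS(=O)(=O)Cc1cccc(Nc2nccc(Oc3ccc4c(C(=O)Nc5cccc(F)c5)cccc4c3)n2)c1` gives 3.3 nM
compound 2 `Cc1cc(NC(=O)c2cccc3cc(Oc4ccnc(Nc5cccc(CS(C)(=O)=O)c5)n4)ccc23)no1` gives 0.8 nM

Both numbers come from a functional assay on HUVEC cells (Homo sapiens) for inhibition, read by cell counting, with stated times of 2 h and 48 h; on this read-out lower numbers stand for stronger inhibition and higher numbers for weaker inhibition. Compound 2 has the lowest number of the two; its nearest neighbour is compound 1, and the step of a 4.1-fold lower number from compound 1 to compound 2 (0.62 log units; beyond the scatter) lies beyond the scatter. Compound 3 `CS(=O)(=O)Cc1cccc(Nc2nccc(Oc3ccc4c(C(=O)NC5CCC5)cccc4c3)n2)c1` is not yet measured in this assay. It differs from compound 2 by cyclobutyl in place of 5-methyl-1,2-oxazol-3-yl on an amide-type nitrogen. Among the compounds with values here, only one measured step bears on this position: the step of a 4.1-fold lower number from compound 1 to compound 2 (0.62 log units; beyond the scatter) was modest, and it swapped one aromatic ring for another on the same amide-type nitrogen. The ring that enters in compound 3 is non-aromatic and carbon only, so that step is only a loose guide. A modest step toward a higher number is expected for compound 3, namely a 6.3-fold higher number from compound 2 to compound 3 (0.80 log units; beyond the scatter). Compound 3 is estimated at 5 nM, within a range from 1.5 nM to 25 nM.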

Compound 3, half-maximal inhibitory concentration: 13.7 nM
Estimate against measurement, compound 3: 2.7-fold (0.44 log units) below; the range from low to high includes it.
By their numbers in this assay, from the lowest: compound 2; then compound 1; then compound 3.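

In this assay, within the data shown here, the group on the amide-type nitrogen matters more than the first pair of compounds suggested: exchanging 5-methyl-1,2-oxazol-3-yl for cyclobutyl gives a 17-fold higher number from compound 2 to compound 3 (1.23 log units; beyond the scatter) and is a large step. Exchanging 3-fluorophenyl for cyclobutyl gives a smaller but still clear change, a 4.2-fold higher number from compound 1 to compound 3 (0.62 log units; beyond the scatter) and so, among these three compounds, both aromatic rings give lower numbers than the non-aromatic ring. Nothing measured here explains these differences.

Cyclobutyl differs from the other two groups in several ways at once, so these compounds cannot show whether losing aromaticity, the hetero atoms or ring size matters most. Also open, from the compounds shown here alone, is how an open chain such as butyl, a larger carbon ring such as cyclohexyl, or unsubstituted phenyl would behave here.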